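Vero cytotoxicity across the shared core: methyl to chloro

The source may hold more compounds than are shown below. What is called first, only, known or untested is meant among the compounds shown, and "the series" means these compounds.

Working notes on the series. Compound 1 `COC(=O)/C=C1\Nc2cc(-c3ccccc3)ccc2OC1=O` has no result in an ADME assay on Vero cells (Chlorocebus sabaeus) for cytotoxicity, read by MTT assay, with a stated time of 72 h (on this read-out lower numbers stand for higher toxicity in this test and higher numbers for lower toxicity in this test), and is recorded as "not determined" (no result reported). Compound 2 `O=C1Oc2ccccc2N/C1=C\C(=O)c1ccc(-c2ccccc2)cc1` reaches only a limit of this assay, > 366000 nM. Compound 3 `Cc1ccccc1C(=O)/C=C1\Nc2ccccc2OC1=O` likewise reaches only a limit of this assay, > 1790000 nM. Where compound 3 stands on the numbers shown is thus only as a limit (the limit of > 1790000 nM in this assay, at which 1 of the 3 values shown sits), with the other reported value also a limit of > 366000 nM in this assay, at which 1 of the 3 values shown sits, and the remaining entry without a number, so no compound can be ranked against another here.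

Compound 4 `O=C1Oc2ccccc2N/C1=C\C(=O)c1ccccc1Cl` differs from compound 3 by chloro in place of methyl on an aromatic carbon, the 2-methylphenyl becoming 2-chlorophenyl. For the measured compounds named here, no step between measured compounds is available for this change. Given that every reported value of the series sits at a limit, no shift beyond the usual scatter is expected, and the step from compound 3 to compound 4 is estimated as an at least 1.1-fold lower number from compound 3 to compound 4 (0.07 log units; that floor lies within the scatter). Compound 4 is accordingly expected to give 1500000 nM in this assay, within 300000 nM to 5000000 nM, most probably reported again only as a limit.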

Compound 4, half-maximal cytotoxic concentration: 1570000 nM
The estimate for compound 4 lay 1.0-fold (0.02 log units) below the measured number; low and high end bracket the measured number.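

For the compounds shown here, with chloro in place of methyl on an aromatic carbon, ortho to a large group, this assay yields the first actual number of the series rather than a limit: compound 4 gives 1570000 nM. The change from 2-methylphenyl to 2-chlorophenyl reads as an at least 1.1-fold lower number from compound 3 to compound 4 (0.05 log units; that floor lies within the scatter), so the data show no shift beyond the scatter, though the true step may be larger than this floor. The step can be read only as a floor because compound 3 stands at a limit: the limit of > 1790000 nM in this assay, at which 1 of the 4 values shown sits.

Open, on these data alone, is whether another group at this position, such as an amine, a carboxylic acid or a longer chain, would bring the number clearly down. Going by these compounds alone, compound 1 and compound 2 each differ from compound 4 in more than one place, so they add no step.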